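This account rests on a few compounds, and the source may have more. Where it says the series, first, only, none or still open, it means among the compounds named here.

Four compounds share one core. Compound 1 `COc1ccc2c(c1)CCc1c-2c2c(c3c4ccccc4n(CCCO)c13)CNC2=O` gives 101 nM in an assay on isolated protein for inhibition of mitogen-activated protein kinase kinase kinase 9 (Homo sapiens); on this read-out lower numbers stand for stronger inhibition and higher numbers for weaker inhibition. Compound 3 `CC(C)Oc1ccc2c(c1)CCc1c-2c2c(c3c1[nH]c1ccccc13)CNC2=O` gives 66 nM in this assay. Compound 2 `O=C1NCc2c1c1c(c3c2c2ccccc2n3CCO)CCc2cc(OCCO)ccc2-1` has no single number to stand on: in this assay compound 2 is reported as "not determined" (no result reported), so its place among the others cannot be stated. Compound 4 `O=C1NCc2c1c1c(c3c2c2ccccc2n3CCO)CCc2cc(OC3CCCC3)ccc2-1` differs from compound 2 by cyclopentyl in place of 2-hydroxyethyl on an oxygen on an aromatic ring. Going by the values given here, no measured pair shows this change, so the step in this assay from compound 2 to compound 4 is expected to stay within the usual scatter in either direction, judged against compound 1 at 101 nM and compound 3 at 66 nM. For compound 4 the expected value in this assay is 70 nM, with a range from 25 nM to 200 nM.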

Compound 4, half-maximal inhibitory concentration: 49 nM
For compound 4 the middle estimate is 1.4-fold (0.15 log units) above the measured one, and the stated range covers the measured number.
By their numbers in this assay, from the lowest: compounds 4, 3 and 1 (each within the scatter of the next, the first and the last beyond it).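

Going by these compounds alone, compound 4 yields no new step: compound 2, which differs from it in one place, has no number in this assay. On these data alone, what changing 2-hydroxyethoxy to cyclopentyloxy does on its own stays open, and no further evidence bears on this result.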